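The source may report more compounds than this note shows. Statements on the series, on what has been measured and on what is new or still open speak of the compounds shown alone.

Series notes. Compound 1 `C=C(Br)C(=O)Nc1cccc(-c2cn3nc(-c4ccc(OCC)cc4)sc3n2)c1` stands lowest of the three numbers in hand for a functional assay on FM3A cells (Mus musculus) for inhibition, read by cell counting, with a stated time of 2 days (a lower number here means a stronger inhibitor, a higher number a weaker inhibitor), where compound 1 gives 1100 nM. Compound 3 `Nc1cccc(-c2cn3c(-c4ccc(Cl)cc4)csc3n2)c1` is the nearest of the others, and in this assay compound 3 gives 11000 nM, a gap that lies beyond the usual scatter. Compound 2 `COc1cccc(-c2nn3cc(-c4cccc(N)c4)nc3s2)c1` is the furthest; in this assay compound 2 gives 29000 nM, again beyond the scatter. For the measured compounds named here, no two of these three compounds differ in only one place, so no single-change step within the measured set is available for comparison.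

Compound 4 `C=C(Br)C(=O)Nc1cccc(-c2cn3nc(Cc4cccc(OC)c4)sc3n2)c1` keeps the rest of compound 1 and has the same atoms, joined differently: 3-methoxybenzyl in place of 4-ethoxyphenyl on an aromatic carbon. The group that leaves, 4-ethoxyphenyl, sits on an aromatic carbon of a five-membered aromatic ring with 2 nitrogen and 1 sulfur, part of a fused or bridged system of two rings, and 3-methoxybenzyl enters at that same carbon. The measured compounds give no guide to the effect of this exchange, so the expectation rests on the change itself. The step of a 2.7-fold higher number from compound 1 to compound 4 (0.44 log units; beyond the scatter) is expected to be modest and toward a higher number, though a result within the scatter would not surprise. Compound 4 is estimated at 3000 nM in this assay, with a range from 900 nM to 12000 nM.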

Compound 4, half-maximal inhibitory concentration: 1100 nM
Compound 4: middle estimate off by 2.7-fold (0.44 log units), on the high side, within the range that was stated.
By their numbers in this assay, from the lowest: compounds 1 and 4 (each within the scatter of the next); then compound 3; then compound 2.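

Read in this assay, the exchange of 4-ethoxyphenyl for 3-methoxybenzyl gives no change at the digits printed from compound 1 to compound 4 (within the scatter), and this is the first single-change reading at this aromatic carbon, next to the ring nitrogen and next to the ring sulfur. The two groups have the same heavy atoms and the same counts of donors and acceptors, so this pair shows that rearranging those atoms, with the ring set one carbon away from the shared core and the oxygen substituent placed differently on it, need not move the number beyond the scatter, though this rests on one pair alone. Nothing in hand accounts for this outcome, and no measurement bears on it.

Still open, on these data alone, is whether this carbon accepts a group of another kind, such as a longer alkyl chain with no ring, a benzyl group carrying an amine, or one carrying a carboxylic acid, in place of the two groups compared here. Compound 2 and compound 3 each differ from compound 1 in more than one place, so the contribution of the bromine-bearing amide to the numbers of compound 1 and compound 4 also remains unresolved.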